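Swapping the benzylic halophenyl for a trifluoromethylphenyl group

The source may report more compounds than this note shows. Statements on the series, on what has been measured and on what is new or still open speak of the compounds shown alone.

Compound 3 `O=C(NC1CCN(Cc2cccc(Br)c2)CC1)c1ccc2ccccc2c1` gives 36 nM in an assay on isolated protein for displacement of a labelled ligand from D(4) dopamine receptor (Homo sapiens) (a lower number here means a stronger inhibitor, a higher number a weaker inhibitor), the lowest number among the three measured compounds. Compound 2 `O=C(NC1CCN(Cc2ccc(Cl)cc2)CC1)c1ccc2ccccc2c1` gives 37 nM, and the step of a 1.0-fold lower number from compound 2 to compound 3 (0.01 log units; within the scatter) shows the two halophenyl groups as interchangeable here. Compound 1 `O=C(NC1CCN(Cc2ccc(C(F)(F)F)cc2)CC1)c1cccc2ccccc12`, which differs in its core as well, gives 96 nM.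

Compound 4 `O=C(NC1CCN(Cc2ccc(C(F)(F)F)cc2)CC1)c1ccc2ccccc2c1` arises from compound 3 by 4-(trifluoromethyl)phenyl in place of 3-bromophenyl on a saturated chain carbon bound to an amine nitrogen in a ring. Going by the values given here, the one measured step on this position is a 1.0-fold lower number from compound 2 to compound 3 (0.01 log units; within the scatter), so swapping one substituted phenyl for another has so far moved nothing beyond the scatter. Compound 1, which also bears the 4-(trifluoromethyl)phenyl group, shows a weaker number, but its core differs, so the expected step of a 1.4-fold higher number from compound 3 to compound 4 (0.14 log units; within the scatter) is small. Compound 4 is thus estimated at 50 nM, ranging from 20 nM to 130 nM.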

Compound 4, inhibition constant: 84 nM
Compound 4: middle estimate off by 1.7-fold (0.23 log units), on the low side; the range from low to high includes it.
By their numbers in this assay, from the lowest: compounds 3 and 2 (each within the scatter of the next); then compounds 4 and 1 (each within the scatter of the next).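

Unlike the exchange of one halophenyl group for the other, the 4-(trifluoromethyl)phenyl group moves the number beyond the scatter in this assay: there is a 2.3-fold higher number from compound 3 to compound 4 (0.37 log units; beyond the scatter) and, with trifluoromethyl in place of chloro on an aromatic carbon, a 2.3-fold higher number from compound 2 to compound 4 (0.36 log units; beyond the scatter) as well. Naphthalen-2-yl in place of naphthalen-1-yl on a carbonyl carbon gives a 1.1-fold lower number from compound 1 to compound 4 (0.06 log units; within the scatter) with this group, so the two cores do not separate here. Nothing measured explains the weaker binding.

Still open, on these data alone, is how a 3-(trifluoromethyl)phenyl group would compare, which would separate the group from its place on the phenyl ring. A 4-methoxyphenyl group would show whether the loss extends beyond trifluoromethyl.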